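The source may hold more compounds than are shown below. What is called first, only, known or untested is meant among the compounds shown, and "the series" means these compounds.

Compound 1 `CC(C)(C)n1ncc(OCc2nnc(-c3ccc(Cl)cc3)s2)c(Cl)c1=O` is assessed in a functional assay on the whole organism for inhibition, with Mythimna separata as the target, with a stated time of 5 days (a higher number here means that more compound is needed for the effect, a lower number that less compound is needed), where compound 1 gives 106000 nM, the lowest of the two numbers shown. Compound 2 `CC(C)(C)n1ncc(OCc2nnc(-c3c(F)c(F)c(F)c(F)c3F)o2)c(Cl)c1=O` gives 271000 nM in this assay, a gap beyond the scatter. Compound 3 `Cc1cc(C)cc(-c2nnc(COc3cnn(C(C)(C)C)c(=O)c3Cl)o2)c1` reaches only a limit of the assay, (the limit of > 299000 nM in this assay, at which 1 of the 3 values shown sits), and compound 3 gives > 299000 nM. The account now turns to compound 4 `CC(C)(C)n1ncc(OCc2nnc(-c3ccccc3F)s2)c(Cl)c1=O`, which differs from compound 1 by 2-fluorophenyl in place of 4-chlorophenyl on an aromatic carbon. No step between two measured compounds matches this change, so the expectation rests on the spread of the numbers already shown. Compound 4 is expected to give about 170000 nM, with a range from 60000 nM to 450000 nM. The step from compound 1 to compound 4 is estimated at a 1.6-fold higher number from compound 1 to compound 4 (0.21 log units; within the scatter), a modest loss, since compound 2 with its altered aryl group gives 271000 nM.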

Compound 4, half-maximal effective concentration: 121000 nM
Beside the measured number, compound 4's estimate is 1.4-fold (0.15 log units) above it; measured number inside the range.
By their numbers in this assay, from the lowest: compounds 1 and 4 (each within the scatter of the next); then compound 2. At a limit, above all of these: compound 3.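

For the compounds shown here, the pair of compound 1 and compound 4 is the first to differ in one place, and in this assay the change gives a 1.1-fold higher number from compound 1 to compound 4 (0.06 log units; within the scatter). On this aromatic carbon, 2-fluorophenyl and 4-chlorophenyl therefore cannot be told apart, although this covers only these two groups. Nothing measured here offers a reason for this result.

Going by these compounds, whether an amine or a carboxylic acid on the phenyl ring, or a longer chain in its place, would move the number beyond the scatter remains open.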